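The source may report more compounds than this note shows. Statements on the series, on what has been measured and on what is new or still open speak of the compounds shown alone.

Compound 1 `O=C(/C(=C\c1ccc(F)cc1F)Sc1ccc(Br)cc1)c1ccc(Br)cc1` and compound 2 `Cc1ccc(CS/C(=C/c2c[nH]c3ccc(Cl)cc23)C(=O)c2ccc(Cl)cc2)cc1` share a core and were both tested in a functional assay on DU-145 cells (Homo sapiens) for inhibition, read by trypan blue exclusion, with a stated time of 96 h; a lower number here means a stronger inhibitor of growth, a higher number a weaker inhibitor of growth. Compound 1 gives 1000 nM in this assay. Compound 2 gives 1000 nM in this assay, level with compound 1 at the digits shown, so the two lie within the scatter of each other and no order between them can be claimed. Compound 3 `Cc1ccc(CS/C(=C/c2cc([N+](=O)[O-])ccc2F)C(=O)c2ccc(Cl)cc2)cc1` has not yet been measured. It differs from compound 2 in one place: 2-fluoro-5-nitrophenyl in place of 5-chloro-1H-indol-3-yl on a double-bonded chain carbon bound to a double-bonded chain carbon. Compound 1 already carries a plain six-membered carbon ring on a double-bonded chain carbon bound to a double-bonded chain carbon, and it reads the same as compound 2, so no step beyond the scatter is expected for no change at the digits printed from compound 2 to compound 3 (within the scatter). Compound 3 is therefore estimated at 1000 nM in this assay, with a range from 300 nM to 3000 nM.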

Compound 3, concentration for 50% growth inhibition: 1000 nM
Compound 3: middle estimate and measured number agree at the digits printed; low and high end bracket the measured number.
By their numbers in this assay, from the lowest: compounds 1, 2 and 3 (each within the scatter of the next).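

In this assay, putting 2-fluoro-5-nitrophenyl in place of 5-chloro-1H-indol-3-yl on a double-bonded chain carbon bound to a double-bonded chain carbon gives no change at the digits printed from compound 2 to compound 3 (within the scatter) for this pair. Among these compounds, this is the first direct one-place comparison at this position, and it spans a broad exchange: a group with two aromatic rings and 1 hydrogen-bond donor leaves, while a group with one aromatic ring, 0 hydrogen-bond donors and 2 hydrogen-bond acceptors enters, with 10 heavy atoms on each side. No supporting data are available to explain why the reading stays within the scatter.

Going by these compounds, whether a carboxylic acid or an amine at this place would shift the reading remains open. It is also unclear how the fluorine and the nitro group each contribute within the entering group.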